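Trifluoromethoxy in Place of Trifluoromethyl on an Aromatic Carbon

The source may hold more compounds than are shown below. What is called first, only, known or untested is meant among the compounds shown, and "the series" means these compounds.

In an ADME assay on L6 cells (Rattus norvegicus) for cytotoxicity (on this read-out higher numbers stand for weaker inhibition and lower numbers for stronger inhibition), compound 1 (`O=C(NCCCCn1cnc([N+](=O)[O-])n1)c1ccc(OC(F)(F)F)cc1`) reports only a limit, > 268000 nM. Among the measured compounds shown here, compound 2 (`O=[N+]([O-])c1ncn(CCCCNS(=O)(=O)c2ccc(C(F)(F)F)cc2)n1`) gives 84900 nM, the only actual number so far in this assay. Compound 3 (`O=[N+]([O-])c1ncn(CCCCNS(=O)(=O)c2ccc(OC(F)(F)F)cc2)n1`) carries trifluoromethoxy in place of trifluoromethyl on an aromatic carbon, para to a large group: trifluoromethoxy in place of trifluoromethyl on an aromatic carbon. For the measured compounds named here, no measured step covers such an exchange, and no shift beyond the usual scatter of this assay is expected. The expected step of a 1.2-fold lower number from compound 2 to compound 3 (0.08 log units; within the scatter) is therefore small and has no firm direction. For compound 3 the estimated value is 70000 nM, with an expected range from 28000 nM to 180000 nM.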

Compound 3, half-maximal inhibitory concentration: 112000 nM
Beside the measured number, compound 3's estimate is 1.6-fold (0.20 log units) below it; the measured number falls inside the stated range.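

In this assay, placing trifluoromethoxy in place of trifluoromethyl on an aromatic carbon gives a 1.3-fold higher number from compound 2 to compound 3 (0.12 log units; within the scatter). This is the first measured step among these compounds, and it shows that this exchange, para to a large group, leaves the read-out within the scatter. Compound 1 reports only a limit, so no step to it can be read: the limit of > 268000 nM in this assay, at which 1 of the 3 values shown sits.

Still open, going by these compounds, is whether an amine or a carboxylic acid at this position would move the number beyond the scatter. Whether a longer chain would do so is open too.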